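Shrinking the Ester Tail: From Benzyl to Ethyl

The source may report more compounds than this note shows. Statements on the series, on what has been measured and on what is new or still open speak of the compounds shown alone.

Compound 1 `NCc1ccc(C(=O)Nc2ccncc2)cc1-c1cccc(C(=O)OCC2CCCCC2)c1`: 48 nM
Compound 2 `NCc1ccc(C(=O)Nc2ccncc2)cc1-c1cccc(C(=O)OCc2ccccc2)c1`: 45 nM
Compound 3 `CC(C)OCCOC(=O)c1cccc(-c2cc(C(=O)Nc3ccncc3F)ccc2CN)c1`: 37 nM

All three were tested in an assay on isolated protein for inhibition of Rho-associated protein kinase 2 (Homo sapiens), read by radiometric assay; on this read-out lower numbers stand for stronger inhibition and higher numbers for weaker inhibition. Compound 2 has the second highest of the three numbers, yet its gaps to compound 1 and compound 3 both lie within the scatter. Compound 4 `CCOC(=O)c1cccc(-c2cc(C(=O)Nc3ccncc3)ccc2CN)c1` carries methyl in place of phenyl on a saturated chain carbon bound to an oxygen next to a carbonyl group. Within the data shown here, the one measured step at this place, a 1.1-fold lower number from compound 1 to compound 2 (0.03 log units; within the scatter), exchanged one ring for another and left the number unchanged. Among the measured compounds shown here, no measured pair removes the ring altogether, so that part of the change is untested. Because a 1.1-fold lower number from compound 1 to compound 2 (0.03 log units; within the scatter) showed no shift, the expected step of a 1.1-fold higher number from compound 2 to compound 4 (0.05 log units; within the scatter) is none beyond the scatter. Compound 4 is therefore estimated at 50 nM, within 25 nM to 110 nM.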

Compound 4, half-maximal inhibitory concentration: < 1 nM
Compound 4 was reported as a limit (the forecaster's own chance of this, stated with the estimate: 2%); at least 50-fold (1.69 log units) between middle value and limit.
By their numbers in this assay, from the lowest: compounds 3, 2 and 1 (each within the scatter of the next). At a limit, below all of these: compound 4.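

Swapping one ring for another at this position changed nothing, but replacing the ring with methyl, which turns the benzyl ester into the ethyl ester, has a large effect: an at least 45-fold lower number from compound 2 to compound 4 (1.65 log units; beyond the scatter). The cyclohexyl ester gives the same picture, with an at least 48-fold lower number from compound 1 to compound 4 (1.68 log units; beyond the scatter). In this assay compound 4 is reported only as a limit, < 1 nM, so both steps are minimum sizes: the limit of < 1 nM in this assay, at which 1 of the 4 values shown sits.

As far as these compounds go, the exact value of compound 4 stays open. So does whether a propyl ester, a longer chain or a carboxylic acid at this place would keep the number this low.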